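Anilide aryl exchange: nitro entering on the amide nitrogen

The compounds below may be only part of what the source reports. "The series", "measured", "known", "first", "only" and "open" are said of these compounds alone.

Three members of this series have numbers in a functional assay on Molt4/C8 cells (Homo sapiens) for cytotoxicity; on this read-out higher numbers stand for weaker inhibition and lower numbers for stronger inhibition. Compound 1 `Cc1ccc(NC(=O)/C=C/C(=O)N2C/C(=C\c3ccc([N+](=O)[O-])cc3)C(=O)/C(=C/c3ccc([N+](=O)[O-])cc3)C2)cc1C` gives 660 nM, the lowest of the three. Compound 2 `CC(=O)c1ccc(NC(=O)/C=C/C(=O)N2C/C(=C\c3ccccc3)C(=O)/C(=C/c3ccccc3)C2)cc1` gives 1400 nM, a little above compound 1 and beyond the scatter. Compound 3 `O=C(/C=C/C(=O)N1C/C(=C\c2ccccc2)C(=O)/C(=C/c2ccccc2)C1)Nc1ccc([N+](=O)[O-])cc1` gives 31000 nM, far above both.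

The unmeasured member is compound 4 `O=C(/C=C/C(=O)N1C/C(=C\c2ccc([N+](=O)[O-])cc2)C(=O)/C(=C/c2ccc([N+](=O)[O-])cc2)C1)Nc1ccc([N+](=O)[O-])cc1`. It is reached from compound 1 by one change: 4-nitrophenyl in place of 3,4-dimethylphenyl on an amide-type nitrogen. For the measured compounds named here, the only measured step that touches the anilide aryl is a 22-fold higher number from compound 2 to compound 3 (1.35 log units; beyond the scatter), where nitro entered in place of acetyl on that aromatic carbon, with the same core and no other change. Going by the values given here, no step shows a dimethyl group leaving the same ring, so the distance from compound 1 to compound 4 is not measured directly, and the nitro groups already present on the core of compound 1 have no matching comparison either.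

On the strength of compound 3, whose 31000 nM sits far above compound 2, a large rise in the number is expected for compound 4, estimated as a 14-fold higher number from compound 1 to compound 4 (1.13 log units; beyond the scatter). For compound 4 the estimate in this assay is 9000 nM, with a range from 2500 nM to 35000 nM.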

Compound 4, half-maximal inhibitory concentration: 430 nM
The estimate for compound 4 lay 21-fold (1.32 log units) above the measured number; measured number outside the range, below it.
By their numbers in this assay, from the lowest: compounds 4 and 1 (each within the scatter of the next); then compound 2; then compound 3.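

In this assay the exchange gives a 1.5-fold lower number from compound 1 to compound 4 (0.19 log units; within the scatter), so on the core of compound 1 the 4-nitrophenyl and 3,4-dimethylphenyl groups on this amide-type nitrogen cannot be told apart on this read-out. A nitro group on the anilide aryl therefore does not bring a large rise in the number wherever it enters: the earlier step at this place, a 22-fold higher number from compound 2 to compound 3 (1.35 log units; beyond the scatter), does not recur here, although that step had acetyl leaving on a core without the nitro groups of compound 1. Nothing measured alongside these numbers accounts for the contrast between the two steps.

Whether the contrast follows from the core or from the group that leaves stays open: the two steps differ in both, and no pair shown holds one fixed while the other changes. Also open, on these data alone, is whether an aryl ring carrying an amine or a carboxylic acid in place of the nitro group would stay close to compound 1 or move toward compound 3.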